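Compound 3: one fluoro fewer on the aniline ring

The compounds below may be only part of what the source reports. "The series", "measured", "known", "first", "only" and "open" are said of these compounds alone.

Two compounds have readings so far in an ADME assay on Vero cells (Chlorocebus sabaeus) for cytotoxicity; on this read-out higher numbers stand for lower toxicity in this test and lower numbers for higher toxicity in this test. Compound 1 (`CC(=O)c1c(Nc2ccc(F)cc2F)[nH]c2c(Cl)cc(Cl)c(Cl)c2c1=O`) gives > 25000 nM, which is a limit of the assay and not a number. Among the compounds with values here, compound 2 (`CC(C)C(=O)c1c(Nc2ccc(F)c(F)c2F)[nH]c2c(Cl)cc(Cl)c(Cl)c2c1=O`) gives 6400 nM, the only true number to date, so it serves as the reference point.

The next compound, compound 3 (`CC(C)C(=O)c1c(Nc2ccc(F)cc2F)[nH]c2c(Cl)cc(Cl)c(Cl)c2c1=O`), departs from compound 2 at one place: 2,3,4-trifluorophenyl becomes 2,4-difluorophenyl, with hydrogen in place of fluoro on an aromatic carbon, ortho to two fluoro groups (hydrogen in place of fluoro on an aromatic carbon).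

Within the data shown here, no measured pair sizes this change in this assay. A small shift is expected, close to the scatter and leaning towards higher numbers, meaning lower toxicity in this test. That expectation starts from compound 2 at 6400 nM. The upward lean rests only on compound 1, whose > 25000 nM is a limit. The expected 1.6-fold higher number from compound 2 to compound 3 (0.19 log units; within the scatter) is therefore modest. For compound 3 the estimated value is 10000 nM, with an expected range of 4500 nM to 25000 nM.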

Compound 3, half-maximal cytotoxic concentration: > 25000 nM
Compound 3 ended at the assay's limit; the forecaster's own chance of this, stated with the estimate: 20%; middle value at least 2.5-fold (0.39 log units) from the limit.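

In this assay, within the data shown here, hydrogen in place of fluoro on an aromatic carbon, ortho to two fluoro groups, gives an at least 3.9-fold higher number from compound 2 to compound 3 (0.59 log units; beyond the scatter), the only readable step so far. This shows that the read-out responds to this single atom on the aromatic ring, with isopropyl on the carbonyl carbon and the shared core unchanged. Compound 3 gives > 25000 nM, which is a limit of the assay and not a number, and the step can be stated only as a lower bound because the read-out stops there: the limit of > 25000 nM in this assay, at which 2 of the 3 values shown sit.

The step between the other two compounds cannot be read, as both values are limits, which leaves isopropyl in place of methyl on a carbonyl carbon unsized in this series. Also open, going by these compounds, is how this aromatic carbon behaves with a chloro, methyl or methoxy group in place of fluoro and hydrogen, and whether a result from such a group would fall at a true number or again at the limit.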